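Trifluoroacetyl Amide in Place of a Sulfonamide

A few compounds are considered here, and "the series" means these few. Any claim that something is new, unique, unknown or untested is made for them only; others in the source may bear on it.

Going by the values given here, compound 1 `Cc1ccc(S(=O)(=O)N(Cc2cccc(F)c2F)Cc2cn(S(=O)(=O)c3ccc(F)cc3)c3ccccc23)cc1` is one of three compounds measured in a functional assay on 3T3-L1 cells (Mus musculus) for inhibition, with a stated time of 20 min, tested at 20 uM (on this read-out higher numbers stand for more inhibition at the one concentration tested (going by the name of the read-out) and lower numbers for less inhibition), where compound 1 gives -35%, the lowest of the three numbers. Among the compounds with values here, compound 2 `Cc1ccc(S(=O)(=O)N(Cc2cccc(F)c2F)Cc2cn(S(=O)(=O)c3ccc(C)cc3)c3ccccc23)cc1` differs from it at a single place, and in this assay compound 2 gives -13.9%; that step, a number 21.1 percentage points higher from compound 1 to compound 2 (beyond the scatter), is the only single-point change among the measured compounds. Compound 3 `Cc1ccc(S(=O)(=O)N(Cc2cn(Cc3ccc(F)cc3F)nn2)Cc2c(C)c3ccccc3n2S(=O)(=O)c2ccc(C)cc2)cc1` shares less with compound 1, and in this assay compound 3 gives -22%. Compound 4 `O=C(N(Cc1cccc(F)c1F)Cc1cn(S(=O)(=O)c2ccc(F)cc2)c2ccccc12)C(F)(F)F` has not yet been measured. It differs from compound 1 as follows: (trifluoromethyl)carbonyl in place of (4-methylphenyl)sulfonyl on an amine nitrogen. Within the data shown here, no measured step exchanges the group on the amine nitrogen, so the one recorded step, which concerns a substituent on an aromatic carbon, does not bear directly on this change, and its size offers no guide to the direction here. All three measured numbers in this assay lie below zero, and nothing in them indicates that compound 4 would depart far from that band. Compound 4 is therefore expected to give about -15% in this assay, within an estimated range of -45% to 15%. The step this estimate implies, a number 20 percentage points higher from compound 1 to compound 4 (beyond the scatter), is an expectation with uncertain direction rather than a measured result.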

Compound 4, a percentage reported as inhibition, at one concentration (the size of the read-out at that concentration, not a potency): -52.3%
Beside the measured number, compound 4's estimate is 37.3 percentage points above it; measured number below the stated range.
By their numbers in this assay, from the lowest: compound 4; then compound 1; then compounds 3 and 2 (each within the scatter of the next).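

Going by these compounds alone, this is the first measured exchange on the amine nitrogen, since the only earlier step concerned a substituent on an aromatic carbon. In this assay, replacing (4-methylphenyl)sulfonyl with (trifluoromethyl)carbonyl gives a number 17.3 percentage points lower from compound 1 to compound 4 (beyond the scatter), so the read-out responds to the group on this nitrogen, and the direction is towards less inhibition on this scale. The change removes the six-membered aromatic ring and takes the group from 10 heavy atoms to 6, yet the number stays below zero and does not move back towards it, so within this pair, losing that ring and sulfonyl unit does not bring the value nearer to zero.

Within the data shown here, the single pair cannot separate the loss of the aromatic ring from the exchange of sulfonyl for carbonyl, or the carbonyl from its three fluorine atoms, and an acetyl, a benzoyl or a methanesulfonyl group on the same nitrogen would be needed to pull these apart. No measurement bears on what lies behind the step, which therefore stands here as an observation without an explanation.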